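Chloro on the aryl imine of compound 1

The source may report more compounds than this note shows. Statements on the series, on what has been measured and on what is new or still open speak of the compounds shown alone.

Measured in a functional assay on MDA-MB-231 cells (Homo sapiens) for antiproliferative activity, read by sulforhodamine B assay; a lower number here means a stronger inhibitor of growth, a higher number a weaker inhibitor of growth:
compound 1 `CC1CC(=O)c2s/c(=N/c3ccccc3)oc2C1` gives 2310 nM
compound 2 `CC1(C)CC(=O)c2s/c(=N/C3CCCCC3)oc2C1` gives 13100 nM
compound 3 `CC(C)C1CC(=O)c2s/c(=N/C3CCCCC3)oc2C1` gives 5900 nM

Compound 1 stands lowest of the three numbers in this assay; compound 3 is nearest and compound 2 furthest, both beyond the scatter, so compound 1 is the strongest inhibitor of growth among the measured set. Compound 4 `CC1CC(=O)c2s/c(=N/c3ccc(Cl)cc3)oc2C1` differs from compound 1 by chloro in place of hydrogen on an aromatic carbon. Among the measured compounds shown here, no measured pair shows this change, so the step is not anchored. A small downward step is expected, a 1.5-fold lower number from compound 1 to compound 4 (0.19 log units; within the scatter), close to or just beyond the scatter. Compound 4 is thus estimated at 1500 nM, within 500 nM to 4500 nM.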

Compound 4, concentration for 50% growth inhibition: 14300 nM
The estimate for compound 4 lay 9.5-fold (0.98 log units) below the measured number, outside the stated range (above it).
By their numbers in this assay, from the lowest: compound 1; then compound 3; then compounds 2 and 4 (each within the scatter of the next).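

In this assay, chloro in place of hydrogen on an aromatic carbon, para to a large group, gives a 6.2-fold higher number from compound 1 to compound 4 (0.79 log units; beyond the scatter) and so weakens growth inhibition. Among the compounds shown here, this is the first one-place step, and it shows that this position of compound 1 does not take chloro without a loss. Nothing measured here accounts for that loss.

The compounds shown leave open whether fluoro or methoxy at the same place would bring a similar loss. Also open, as far as these compounds go, is whether chloro on another carbon of that ring would do so.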